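A few compounds are considered here, and "the series" means these few. Any claim that something is new, unique, unknown or untested is made for them only; others in the source may bear on it.

In a functional assay on A-375 cells (Homo sapiens) for activation, with a stated time of 3 days (a higher number here means that more compound is needed for the effect, a lower number that less compound is needed), three compounds that differ only in one aromatic group have been measured. Compound 1 `O=C(Nc1ccc(-c2ccccn2)cc1)C1CCCN(Cc2ccc(F)c(F)c2)C1` gives 11000 nM, compound 2 `O=C(Nc1ccc(-c2c[nH]cn2)cc1)C1CCCN(Cc2ccc(F)c(F)c2)C1` gives 16000 nM, and compound 3 `O=C(Nc1ccc(-c2ccoc2)cc1)C1CCCN(Cc2ccc(F)c(F)c2)C1` gives 3000 nM, the lowest of the three numbers. Compound 4 `O=C(Nc1ccc(-c2ccsc2)cc1)C1CCCN(Cc2ccc(F)c(F)c2)C1` has thiophen-3-yl in place of furan-3-yl on an aromatic carbon. Going by the values given here, no measured step makes this exact swap. The closest evidence is a 3.7-fold lower number from compound 1 to compound 3 (0.56 log units; beyond the scatter) and a 5.3-fold lower number from compound 2 to compound 3 (0.73 log units; beyond the scatter), both modest, while a 1.5-fold higher number from compound 1 to compound 2 (0.16 log units; within the scatter) shows that another swap of this group changed little. The two groups match in every counted feature, so no step beyond the scatter is expected. The expected change is a 1.2-fold lower number from compound 3 to compound 4 (0.08 log units; within the scatter). For compound 4 the estimate is 2500 nM, with an expected range of 1000 nM to 6500 nM.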

Compound 4, half-maximal effective concentration: 1930 nM
Beside the measured number, compound 4's estimate is 1.3-fold (0.11 log units) above it; the range from low to high includes it.
By their numbers in this assay, from the lowest: compounds 4 and 3 (each within the scatter of the next); then compounds 1 and 2 (each within the scatter of the next).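

Putting thiophen-3-yl in place of furan-3-yl on this aromatic carbon hardly moves the number, giving a 1.6-fold lower number from compound 3 to compound 4 (0.19 log units; within the scatter). Both of these groups stand apart from the pyridin-2-yl and 1H-imidazol-4-yl groups, with a 5.7-fold lower number from compound 1 to compound 4 (0.76 log units; beyond the scatter) and an 8.3-fold lower number from compound 2 to compound 4 (0.92 log units; beyond the scatter), and compound 2, whose group is also a five-membered ring, goes against any rule based on ring size alone. No measurement here explains these differences.

The compounds shown leave open how a plain phenyl group would read at this place, and whether a methyl group or an amine on the thiophen-3-yl ring would lower the number further.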